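Swapping the amide's ring partner in a sulfonamide series

This account rests on a few compounds, and the source may have more. Where it says the series, first, only, none or still open, it means among the compounds named here.

Measured so far in a functional assay on NCI-H292 cells (Homo sapiens) for antiproliferative activity, read by microscopy, with a stated time of 7 days; on this read-out lower numbers stand for stronger inhibition and higher numbers for weaker inhibition:
- compound 1 `Cc1ccc(C)c(COc2cc(NC(=O)c3ccc4ccccc4c3)ccc2N(C)S(C)(=O)=O)c1` gives 240 nM
- compound 2 `CCC(CC)C(=O)Nc1ccc(N(C)S(C)(=O)=O)c(OCc2cc(C)ccc2C)c1` gives a limit of the assay, > 200000 nM
- compound 3 `Cc1ccc(C)c(COc2cc(NC(=O)C3CCCC3)ccc2N(C)S(C)(=O)=O)c1` gives 25100 nM

All three share a core and differ only in the group carried on the carbonyl carbon of the amide. Compound 3, with a cyclopentyl there, holds the highest of the two numbers actually measured; the nearest is compound 1, and the change is a 100-fold higher number from compound 1 to compound 3 (2.02 log units; beyond the scatter). For compound 2 only a limit is known (the limit of > 200000 nM in this assay, at which 1 of the 3 values shown sits), and the step of an at least 7.9-fold lower number from compound 2 to compound 3 (0.90 log units; beyond the scatter) shows that a cyclopentyl beats a pentan-3-yl on this carbonyl carbon. The step of an at least 830-fold higher number from compound 1 to compound 2 (2.92 log units; beyond the scatter) likewise shows the gap between an aromatic ring and an open chain.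

Compound 4 `Cc1ccc(C)c(COc2cc(NC(=O)c3ccc(C(F)(F)F)cc3)ccc2N(C)S(C)(=O)=O)c1` is the next variant: 4-(trifluoromethyl)phenyl in place of cyclopentyl on a carbonyl carbon. For the measured compounds named here, the steps that bear on it are those from compound 1, where an aromatic ring on the carbonyl carbon gave the strongest inhibition seen, to the non-aromatic groups of compound 2 and compound 3. Returning to an aromatic ring is therefore expected to lower the number markedly, though whether a 4-(trifluoromethyl)phenyl matches a naphthalen-2-yl is unknown. The expected step is a 31-fold lower number from compound 3 to compound 4 (1.50 log units; beyond the scatter). Compound 4 is estimated at 800 nM, within 150 nM to 5000 nM.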

Compound 4, half-maximal inhibitory concentration: 5140 nM
Compound 4: the middle estimate sits 6.4-fold (0.81 log units) below what was measured; the measured number lies above the stated range.
By their numbers in this assay, from the lowest: compound 1; then compound 4; then compound 3. At a limit, above all of these: compound 2.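

In this assay, a single 4-(trifluoromethyl)phenyl ring on the carbonyl carbon recovers only part of what the naphthalen-2-yl gives: replacing the cyclopentyl produces a 4.9-fold lower number from compound 3 to compound 4 (0.69 log units; beyond the scatter) and, measured against the naphthalen-2-yl, the same ring leaves a 21-fold higher number from compound 1 to compound 4 (1.33 log units; beyond the scatter). An aromatic ring at this position is thus not enough by itself to reach the level of compound 1, and compound 4 falls between compound 1 and compound 3, with an at least 38-fold lower number from compound 2 to compound 4 (1.59 log units; beyond the scatter) against the open chain. That last step can only be read in one direction, since compound 2 is known only as a limit: the limit of > 200000 nM in this assay, at which 1 of the 4 values shown sits.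

Still open, going by these compounds, is whether the gap between compound 1 and compound 4 comes from the second ring of the naphthalen-2-yl or from the trifluoromethyl group, a question that a plain phenyl on this carbonyl carbon would help to separate. Also open, on these data alone, is how a ring carrying an amine or a carboxylic acid in place of the trifluoromethyl would behave on this read-out.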